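A few compounds are considered here, and "the series" means these few. Any claim that something is new, unique, unknown or untested is made for them only; others in the source may bear on it.

Compound 3 `O=C1C(=O)N(Cc2ccc(-c3cccnc3)cc2)c2ccc(OC(F)(F)F)cc21` serves as the starting point for this step. In a functional assay on CHO cells for positive allosteric modulation of muscarinic acetylcholine receptor M5 (Homo sapiens), read by FLIPR and calcium flux, with a stated time of 1 h (a higher number here means a larger maximal response, a lower number a smaller maximal response), compound 3 gives 51%, the highest of the two numbers shown. Compound 2 `O=C1C(=O)N(Cc2ccc(-c3ccccc3)cn2)c2ccc(OC(F)(F)F)cc21` gives 47% in this assay, a value that lies within the usual scatter of that of compound 3, so the two cannot be told apart. Compound 1 `O=C1C(=O)N(Cc2ccc(-c3ccccc3)cc2)c2ccc(OC(F)(F)F)cc21` gives < 60% in this assay, which is a limit of the assay rather than a number. The step from compound 1 to compound 3 is a step that the limit leaves unreadable from compound 1 to compound 3; its size cannot be read because of the limit of < 60% in this assay, at which 1 of the 3 values shown sits. Compound 4 `O=C1C(=O)N(Cc2ccc(Oc3ccccn3)cc2)c2ccc(OC(F)(F)F)cc21` has not yet been measured. It differs from compound 3 in one place: (pyridin-2-yl)oxy in place of pyridin-3-yl on an aromatic carbon. Among the measured compounds shown here, no measured step introduces a (pyridin-2-yl)oxy group, and the one measured step that changes the same part of the molecule is unreadable, so the data give no measured guide to the direction of this change. Compound 4 is therefore expected to sit close to compound 3. The expected step, a number 1 percentage points lower from compound 3 to compound 4 (within the scatter), lies within the scatter. For compound 4 the estimate in this assay is 50%, with a range from 30% to 70%.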

Compound 4, largest response reached (Emax), in percent of the reference or control that the assay uses: 46%
Beside the measured number, compound 4's estimate is 4 percentage points above it; measured number inside the range.
By their numbers in this assay, from the lowest: compounds 4, 2 and 3 (each within the scatter of the next).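

Placing (pyridin-2-yl)oxy instead of pyridin-3-yl on the aromatic carbon para to a large group gives, in this assay, a number 5 percentage points lower from compound 3 to compound 4 (within the scatter), so the two compounds cannot be told apart. Among the compounds shown here, this is the first step at this position whose size can be read, and it shows that the maximal response can stay within the scatter even though the entering group brings an oxygen that the leaving group lacks, with 7 heavy atoms in place of 6 and 2 hydrogen-bond acceptors in place of 1. The steps that start from compound 1 still cannot be read, because the value of compound 1 is a limit of the assay and not a number: the limit of < 60% in this assay, at which 1 of the 4 values shown sits.

The step changes two things at once, the oxygen and the place of the ring nitrogen, so the compounds shown leave open what each does alone, a question that a phenoxy group at this position would help to separate. All the groups shown here carry an aromatic ring, which leaves open how an amine, a carboxylic acid or a longer chain at this position would behave in this assay.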